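Sulfonamide in place of oxazole on the indane core

The source may report more compounds than this note shows. Statements on the series, on what has been measured and on what is new or still open speak of the compounds shown alone.

The shared core carries, on an aromatic carbon, a group that is varied across three measured compounds. Compound 1 `c1ccc(-c2cccc3c2CCC3c2ncc[nH]2)nc1` gives 1150 nM in a functional assay on CHO cells for agonist activity at Alpha-1A adrenergic receptor (Homo sapiens), read by FLIPR and calcium flux; a higher number here means that more compound is needed for the effect, a lower number that less compound is needed. Compound 2 `COc1cccc2c1CCC2c1ncc[nH]1` gives 32 nM, and compound 3 `Cc1oncc1-c1cccc2c1CCC2c1ncc[nH]1` gives 111 nM. Compound 3 stands second highest of the three numbers: its nearest neighbour is compound 2, with a 3.5-fold higher number from compound 2 to compound 3 (0.54 log units; beyond the scatter), while the furthest is compound 1, with a 10-fold lower number from compound 1 to compound 3 (1.02 log units; beyond the scatter). The remaining step, a 36-fold lower number from compound 1 to compound 2 (1.56 log units; beyond the scatter), is the largest of the three.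

Compound 4 `CCS(=O)(=O)Nc1cccc2c1CCC2c1ncc[nH]1` differs from compound 3 by (ethylsulfonyl)amino in place of 5-methyl-1,2-oxazol-4-yl on an aromatic carbon. Going by the values given here, no measured step carries a sulfonamide, so the bearing of the known steps is indirect. They show that exchanging the pyridin-2-yl of compound 1 for a smaller group lowers the number by a large amount, and that the methoxy of compound 2 does better than the ring of compound 3 by a modest amount. An entering group without a ring is therefore expected to yield a modest step, if any, towards a lower number in the assay, with wide uncertainty. Compound 4 is estimated at 60 nM, within 15 nM to 300 nM, which means an expected step of a 1.9-fold lower number from compound 3 to compound 4 (0.27 log units; within the scatter).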

Compound 4, half-maximal effective concentration: 32 nM
Estimate against measurement, compound 4: 1.9-fold (0.27 log units) above, within the range that was stated.
By their numbers in this assay, from the lowest: compounds 2 and 4 (each within the scatter of the next); then compound 3; then compound 1.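

Among the four compounds, the two groups without a ring give the lower numbers at this aromatic carbon: in this assay the (ethylsulfonyl)amino group brings a 3.5-fold lower number from compound 3 to compound 4 (0.54 log units; beyond the scatter) and a 36-fold lower number from compound 1 to compound 4 (1.56 log units; beyond the scatter), and no compound shown goes against this pattern. The 5-methyl-1,2-oxazol-4-yl and (ethylsulfonyl)amino groups are equal in heavy atoms, so the count of heavy atoms alone does not set the number here, while the (ethylsulfonyl)amino group, which adds a hydrogen-bond donor, still gives no change at the digits printed from compound 2 to compound 4 (within the scatter), which leaves it level with methoxy despite the different atoms and larger size. No independent measurement accompanies these results to account for the shifts at this position.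

The compounds shown leave open whether the sulfonyl group or the amide hydrogen matters for this level of response, a question that a plain amine, an acetamide or a sulfonamide carrying a methyl group on its nitrogen would address. They also leave open how the number responds to the length of the chain, as with a methylsulfonylamino or a longer propylsulfonylamino group, and whether a carboxylic acid would fit at this position.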